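The source may report more compounds than this note shows. Statements on the series, on what has been measured and on what is new or still open speak of the compounds shown alone.

Of the compounds shown here, three have so far been measured in a functional assay on the whole organism for agonist activity, with Mus musculus as the target; on this read-out higher numbers stand for an effect only at larger amounts of compound and lower numbers for an effect already at smaller amounts. Compound 1 has the structure `CC1CCC(=O)N1CC#CCn1ccnc1`. In this assay compound 1 gives > 100 mg/kg, which is a limit of the assay and not a number. Compound 2, with the structure `Cc1cncn1CC#CCN1C(=O)CCC1C`, differs from compound 1 by methyl in place of hydrogen on an aromatic carbon. In this assay compound 2 gives > 100 mg/kg, again a limit rather than a number. Because both ends of the comparison are limits, the step that the two limits leave unreadable from compound 1 to compound 2 cannot be read. Compound 3 has the structure `CCOC(=O)N(C)CC#CCn1ccnc1`; the difference between its core and the core of compound 1 is not broken down here. In this assay compound 3 gives > 100 mg/kg, once more a limit of the assay. What the measured values share is the limit of > 100 mg/kg in this assay, at which 3 of the 3 values shown sit.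

Compound 4, with the structure `CCOC(=O)N(C)CC#CCn1cncc1C`, has not yet been measured in this assay. Among the measured compounds shown here, it differs from compound 3 by methyl in place of hydrogen on an aromatic carbon, which is the same change as the one from compound 1 to compound 2, with the same surroundings around the place. For compound 4 the step expected from its parent is a step that the limit leaves unreadable from compound 3 to compound 4, and this expectation rests on compound 1, compound 2 and compound 3 all sitting at the limit of > 100 mg/kg in this assay, at which 3 of the 3 values shown sit. Compound 4 is therefore expected to give 150 mg/kg, most probably reported again only as a limit, within an expected range from 50 mg/kg to 500 mg/kg.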

Compound 4, dose for half-maximal effect: > 100 mg/kg
Compound 4: only a limit was reported (the forecaster's own chance of this, stated with the estimate: 85%); the middle value is on the limit's open side.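

In this assay compound 4 gives > 100 mg/kg, which is a limit of the assay and not a number. Compound 3 also stands at a limit, and the step between compound 3 and compound 4 cannot be read. The compounds shown leave open what dose any of the four would need for half-maximal effect, and whether methyl in place of hydrogen changes that dose at all.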